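Aryl versus cyclohexyl on the three-membered ring

The compounds below may be only part of what the source reports. "The series", "measured", "known", "first", "only" and "open" are said of these compounds alone.

Measured compounds:
compound 1, `CC[C@H](C)[C@H](N)CN(C(=O)[C@@H]1C[C@H]1c1cccc(OC)c1)c1ccc(-c2ccccc2)cc1`: 3000 nM
compound 2, `CC[C@H](C)[C@H](N)CN(C(=O)[C@@H]1C[C@H]1c1ccc(F)cc1)c1ccc(-c2ccccc2)cc1`: 600 nM
compound 3, `CC[C@H](C)[C@H](N)CN(C(=O)[C@@H]1C[C@H]1C1CCCCC1)c1ccc(-c2ccccc2)cc1`: > 25000 nM

All three share one core and differ only in the group on a saturated ring carbon of the three-membered ring. In a functional assay for agonist activity at G protein-coupled receptor 88 (Homo sapiens), read by HTRF and cAMP accumulation (a higher number here means that more compound is needed for the effect, a lower number that less compound is needed), compound 3 gives only a limit, (the limit of > 25000 nM in this assay, at which 1 of the 3 values shown sits), so its true value is not known. Compound 4, `CC[C@H](C)[C@H](N)CN(C(=O)[C@@H]1C[C@H]1c1cc(F)ccc1F)c1ccc(-c2ccccc2)cc1`, is not yet measured. It differs from compound 3 by 2,5-difluorophenyl in place of cyclohexyl on a saturated ring carbon.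

Going by the values given here, two measured steps bear on this change, both running from an aryl group to cyclohexyl: an at least 8.3-fold higher number from compound 1 to compound 3 (0.92 log units; beyond the scatter) and an at least 41-fold higher number from compound 2 to compound 3 (1.61 log units; beyond the scatter). Returning from cyclohexyl to an aryl group is therefore expected to move in the opposite direction, towards lower numbers. Among the compounds with values here, the two aryl compounds themselves are not alike: a 5.0-fold lower number from compound 1 to compound 2 (0.70 log units; beyond the scatter), so the kind of aryl group matters, and 2,5-difluorophenyl has no direct precedent here.

Taking compound 1 and compound 2 as the span within which a fluorinated phenyl is likely to fall, compound 4 is expected at about 1500 nM, within 300 nM to 8000 nM. The step of an at least 16-fold lower number from compound 3 to compound 4 (1.22 log units; beyond the scatter) is thus estimated as a large decrease from the limit of compound 3.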

Compound 4, half-maximal effective concentration: 770 nM
Compound 4: middle estimate off by 1.9-fold (0.29 log units), on the high side; low and high end bracket the measured number.
By their numbers in this assay, from the lowest: compounds 2 and 4 (each within the scatter of the next); then compound 1. At a limit, above all of these: compound 3.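

The step to a third aryl group reads an at least 32-fold lower number from compound 3 to compound 4 (1.51 log units; beyond the scatter) in this assay, so the gap between aryl and cyclohexyl on this saturated ring carbon now holds for 3-methoxyphenyl, 4-fluorophenyl and 2,5-difluorophenyl alike. Among the aryl groups, 2,5-difluorophenyl and 4-fluorophenyl are not told apart, with a 1.3-fold higher number from compound 2 to compound 4 (0.11 log units; within the scatter) as the step between them, whereas replacing 3-methoxyphenyl gives a 3.9-fold lower number from compound 1 to compound 4 (0.59 log units; beyond the scatter) and runs the same way as the change to 4-fluorophenyl. The size of the aryl-to-cyclohexyl gap remains a bound, as compound 3 stands at a limit: the limit of > 25000 nM in this assay, at which 1 of the 4 values shown sits.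

Going by these compounds, whether the lower numbers of compound 2 and compound 4 go with fluorine or only with the loss of 3-methoxy stays open, and unsubstituted phenyl would be the comparison that separates the two readings. Also open, on these data alone, is what this assay would give for a phenyl group carrying an amine, a carboxylic acid or a trifluoromethyl group on this saturated ring carbon.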